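A few compounds are considered here, and "the series" means these few. Any claim that something is new, unique, unknown or untested is made for them only; others in the source may bear on it.

Of the compounds shown here, three share one core and have been tested in a functional assay on CHO.K1 cells for antagonist activity at prostaglandin D2 receptor 2 (Homo sapiens), read by GTPgammaS binding, with a stated time of 1 h; a higher number here means a weaker inhibitor, a lower number a stronger inhibitor. Compound 1 `COC(=O)c1ccc(Cc2c3c(n(CC(=O)O)c2C)CCNC3=O)c(S(=O)(=O)c2ccccc2)c1` gives 11 nM. Compound 2 `COc1cccc(S(=O)(=O)c2ccccc2)c1Cc1c2c(n(CC(=O)O)c1C)CCNC2=O` gives 4500 nM. Compound 3 `COc1cccc(S(=O)(=O)c2ccccc2Cc2c3c(n(CC(=O)O)c2C)CCNC3=O)c1` gives 12 nM. Among these three numbers compound 3 holds the second highest; its nearest neighbour is compound 1, whose number is lower by an amount that lies within the usual scatter of repeated measurements, so no order between compounds 1 and 3 can be read from the data. Its furthest neighbour is compound 2, whose number is higher by an amount well beyond that scatter.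

Compound 4 `Cc1c(Cc2ccccc2S(=O)(=O)N2CCOCC2)c2c(n1CC(=O)O)CCNC2=O` has not yet been measured in this assay. It differs from compound 3 in one place: morpholin-4-yl in place of 3-methoxyphenyl on a sulfonyl sulfur. Going by the values given here, no measured pair in this set shows the same change, so its effect can only be guessed. Because compound 3 gives 12 nM and the aromatic ring on the sulfonyl sulfur is removed, a step to a higher number is expected, of moderate size, from compound 3 to compound 4 an 8.3-fold higher number from compound 3 to compound 4 (0.92 log units; beyond the scatter). Compound 4 is therefore estimated at 100 nM, with a range from 25 nM to 600 nM.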

Compound 4, half-maximal inhibitory concentration: 22 nM
Estimate against measurement, compound 4: 4.5-fold (0.66 log units) above, outside the stated range (below it).
By their numbers in this assay, from the lowest: compounds 1, 3 and 4 (each within the scatter of the next); then compound 2.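

Putting morpholin-4-yl in place of 3-methoxyphenyl on the sulfonyl sulfur gives a 1.8-fold higher number from compound 3 to compound 4 (0.26 log units; within the scatter) in this assay. This shows that, in this pair, the sulfonyl sulfur need not carry an aromatic ring of carbon only: a non-aromatic ring with two hetero atoms gives a number that cannot be told apart from that of compound 3. Nothing available here explains this result.

As far as these compounds go, it remains open whether the same holds for other groups on the sulfonyl sulfur, such as a dimethylamino group, piperidin-1-yl or a simple methyl group. From the compounds shown here alone, it is also open whether morpholin-4-yl would give a different number with the methoxy group placed as in compound 2, which stands at 4500 nM with its phenyl group on the sulfonyl sulfur.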